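From an oxime to an ethoxycarbamoyl group on the shared core

The compounds below may be only part of what the source reports. "The series", "measured", "known", "first", "only" and "open" are said of these compounds alone.

Compound 3 `CC(CCOc1ccc(/C=N/O)cc1)CCN1CCN(c2ccnc(N)c2)C1=O` was tested in an ADME assay on RD cells (Homo sapiens) for cytotoxicity, read by MTT assay, with a stated time of 24 h; a higher number here means that more compound is tolerated, a lower number that less compound is tolerated. Its result is a limit of the assay, > 100000 nM. Compound 1 `CC(CCOc1ccc(-c2noc(C(F)(F)F)n2)cc1)CCN1CCN(c2ccnc(N)c2)C1=O` gives 48100 nM in this assay. Compound 2 `CCc1nc(-c2ccc(OCCC(C)CCN3CCN(c4ccnc(N)c4)C3=O)cc2)no1` reaches a limit in this assay, > 100000 nM. Two steps lie beyond the scatter: an at least 2.0-fold higher number from compound 1 to compound 3 (0.31 log units; beyond the scatter) and an at least 2.0-fold higher number from compound 1 to compound 2 (0.31 log units; beyond the scatter). The third, a step that the two limits leave unreadable from compound 2 to compound 3, cannot be sized because the limit of > 100000 nM in this assay, at which 2 of the 3 values shown sit, holds both ends. Compound 4 `CCONC(=O)c1ccc(OCCC(C)CCN2CCN(c3ccnc(N)c3)C2=O)cc1` differs from compound 3 by a group of 6 heavy atoms (3 carbon, 1 nitrogen, 2 oxygen; no ring) in place of a group of 3 heavy atoms (1 carbon, 1 nitrogen, 1 oxygen; no ring), on an aromatic carbon. For the measured compounds named here, no measured step touches this change, and compound 3 already sits at the limit. Compound 4 is expected to show a number no higher from compound 3 to compound 4 (the limit leaves the size open). The estimate for compound 4 is 100000 nM, within 45000 nM to 220000 nM, most likely reported again only as a limit.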

Compound 4, half-maximal cytotoxic concentration: > 100000 nM
Compound 4 gave a limit, no number (the forecaster's own chance of this, stated with the estimate: 70%); the middle value lies on the limit itself.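

Ethoxycarbamoyl on this aromatic carbon gives an at least 2.0-fold higher number from compound 1 to compound 4 (0.31 log units; beyond the scatter) in this assay, so an open-chain group larger than the oxime also stays clear of the one measured number, held by compound 1. The steps among compound 2, compound 3 and compound 4 cannot be read, and these compounds cannot be ranked, because all three are held at the same end of the range: the limit of > 100000 nM in this assay, at which 3 of the 4 values shown sit.

From the compounds shown here alone, whether an amine or a carboxylic acid on this carbon would give a readable number stays open. So does the effect of a longer chain in place of the ethyl of ethoxycarbamoyl.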